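The source may hold more compounds than are shown below. What is called first, only, known or untested is meant among the compounds shown, and "the series" means these compounds.

Measured so far in a functional assay on A-375 cells (Homo sapiens) for cytotoxicity, read by MTT assay, with a stated time of 48 h; a lower number here means a stronger inhibitor, a higher number a weaker inhibitor:
compound 1 `CC1(C)S[C@@H]2C/C(=C\C(=O)c3ccccc3)C(=O)N2[C@H]1C(=O)OC(c1ccccc1)c1ccccc1` gives > 100000 nM, a limit of the assay, not a number
compound 2 `CC1(C)S[C@@H]2/C(=C\C(=O)c3ccc(Cl)cc3)C(=O)N2[C@H]1C(=O)OC(c1ccccc1)c1ccccc1` gives 48600 nM
compound 3 `CC1(C)S[C@@H]2/C(=C\C(=O)OC(c3ccccc3)c3ccccc3)C(=O)N2[C@H]1C(=O)OC(c1ccccc1)c1ccccc1` gives 9100 nM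

Compound 1 stands at the assay limit (the limit of > 100000 nM in this assay, at which 1 of the 3 values shown sits), with no numerical value of its own. Among the measured compounds shown here, compound 3 shows the lowest number among the three, and compound 2 sits between; no step between them is worked out here, so these are bare values.

Compound 4 `COC(=O)/C=C1\C[C@H]2SC(C)(C)[C@H](C(=O)OC(c3ccccc3)c3ccccc3)N2C1=O` is the unmeasured partner of compound 1. The change is methoxy in place of phenyl on a carbonyl carbon, or benzoyl to methoxycarbonyl one bond further out. For the measured compounds named here, no step between measured compounds exists for this change. A small step is expected, toward stronger inhibition at best, possibly none beyond the scatter, given that compound 1 sits at > 100000 nM. Compound 4 is estimated at 60000 nM, within 15000 nM to 200000 nM, which means an expected step of an at least 1.6-fold lower number from compound 1 to compound 4 (0.22 log units; that floor lies within the scatter).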

Compound 4, half-maximal inhibitory concentration: > 100000 nM
Compound 4 gave a limit, no number; the forecaster's own chance of this, stated with the estimate: 40%; at least 1.6-fold (0.22 log units) between middle value and limit.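

Compound 1 and compound 4 both give a limit and not a number, so no step can be read between them: the limit of > 100000 nM in this assay, at which 2 of the 4 values shown sit. From the compounds shown here alone, what methoxy in place of phenyl on a carbonyl carbon does to inhibition stays open.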